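The source may report more compounds than this note shows. Statements on the series, on what has been measured and on what is new or still open speak of the compounds shown alone.

Compound 1 `CCCCNc1cccc(NC(=O)C(=O)OCC)c1C#N`: 0.3 mg/kg
Compound 2 `CCOC(=O)C(=O)Nc1cccc(N(C)C(C)C)c1C#N`: 0.3 mg/kg

In a functional assay on the whole organism with Rattus norvegicus as the target (a lower number here means that less compound is needed, a higher number that more compound is needed for the effect), compound 2 gives 0.3 mg/kg, level with compound 1. Compound 3 `CCOC(=O)C(=O)Nc1cccc([N+](=O)[O-])c1C#N` carries nitro in place of isopropyl(methyl)amino on an aromatic carbon, ortho to a cyano group: nitro in place of isopropyl(methyl)amino on an aromatic carbon. Going by the values given here, only one measured step bears on this position, no change at the digits printed from compound 1 to compound 2 (within the scatter). Among the compounds with values here, that step exchanged one amino group for another, and no nitro compound has yet been measured, so it offers limited guidance. The expected step is no change at the digits printed from compound 2 to compound 3 (within the scatter), with no direction favoured beyond the scatter. For compound 3 the estimated value is 0.3 mg/kg, with an expected range from 0.08 mg/kg to 1.2 mg/kg.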

Compound 3, dose for half-maximal effect: 0.4 mg/kg
Compound 3: the middle estimate sits 1.3-fold (0.12 log units) below what was measured, and the stated range covers the measured number.
By their numbers in this assay, from the lowest: compounds 1, 2 and 3 (each within the scatter of the next).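

Putting nitro on the aromatic carbon ortho to a cyano group gives a 1.3-fold higher number from compound 2 to compound 3 (0.12 log units; within the scatter) in this assay, and the same swap against the butylamino group gives a 1.3-fold higher number from compound 1 to compound 3 (0.12 log units; within the scatter). Going by these compounds alone, this position had so far carried only amino groups, and the number now stays within the scatter with nitro as well, a group of 3 heavy atoms with no carbon. Nothing available explains this result.

The compounds shown leave open how a hydroxyl group, a carboxylic acid or a longer alkyl chain at this position would read in this assay. They also leave open whether any group here moves the number beyond the scatter.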